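Removing the bromoacrylamide from compound 2: an untested direction

The source may hold more compounds than are shown below. What is called first, only, known or untested is meant among the compounds shown, and "the series" means these compounds.

Measured compounds and their numbers:
- compound 1, `C=C(Br)C(=O)Nc1cccc(-c2cn3nc(-c4ccc(CC)cc4)sc3n2)c1`: 3200 nM
- compound 2, `C=C(Br)C(=O)Nc1cccc(-c2cn3nc(-c4ccc(F)cc4)sc3n2)c1`: 870 nM
- compound 3, `C=C(Br)C(=O)Nc1cccc(-c2cn3nc(-c4ccc(OC)c(OC)c4)sc3n2)c1`: 610 nM

All three share one core and differ only in the aryl group attached to it. In a functional assay on HeLa cells (Homo sapiens) for inhibition, read by cell counting, with a stated time of 4 days (on this read-out lower numbers stand for stronger inhibition and higher numbers for weaker inhibition), compound 2 gives 870 nM, which places it second highest of the three numbers. Its nearest neighbour is compound 3, and the step of a 1.4-fold lower number from compound 2 to compound 3 (0.15 log units; within the scatter) lies within the scatter, so the two cannot be told apart. Its furthest neighbour is compound 1, and the step of a 3.7-fold lower number from compound 1 to compound 2 (0.57 log units; beyond the scatter) is beyond the scatter.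

Compound 4, `Nc1cccc(-c2cn3nc(-c4ccc(F)cc4)sc3n2)c1`, is not yet measured. It differs from compound 2 by hydrogen in place of (1-bromoethenyl)carbonyl on a nitrogen on an aromatic ring. This change sits at the other end of the molecule from every change that has been measured: the steps from compound 1 to compound 2, from compound 1 to compound 3 and from compound 2 to compound 3 all alter the aryl group, not the nitrogen on the aromatic ring. None of them bears on the step to compound 4, so the data give no measured guide to its size or direction.

With that in mind, compound 4 is expected to give a weaker result, 6000 nM, within a wide range from 900 nM to 40000 nM. Among the measured compounds shown here, this estimate means a step of a 6.9-fold higher number from compound 2 to compound 4 (0.84 log units; beyond the scatter), but it rests on no measured step and should be read as a loose expectation.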

Compound 4, half-maximal inhibitory concentration: >= 250000 nM
Compound 4 gave a limit, no number; the forecaster's own chance of this, stated with the estimate: 25%; middle value at least 41-fold (1.61 log units) away from the limit.
By their numbers in this assay, from the lowest: compounds 3 and 2 (each within the scatter of the next); then compound 1. At a limit, above all of these: compound 4.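

In this assay, compound 4 carries a limit and not a number: the limit of >= 250000 nM in this assay, at which 1 of the 4 values shown sits.

Among the compounds shown here, removing the (1-bromoethenyl)carbonyl group and leaving a plain amino group gives an at least 280-fold higher number from compound 2 to compound 4 (2.45 log units; beyond the scatter), and this is the first measured change on this nitrogen. The earlier steps changed only the aryl group, and even the largest of them, a 5.2-fold lower number from compound 1 to compound 3 (0.72 log units; beyond the scatter), is far smaller, so among the compounds shown the group on this nitrogen counts for much more in this read-out than the choice of aryl group.

Which part of the lost group matters stays open: an acrylamide without the bromine, or an acetamide without the double bond, would help to separate the roles of the bromine, the double bond and the carbonyl. Also open is whether the same loss would appear with the 3,4-dimethoxyphenyl group of compound 3 or the 4-ethylphenyl group of compound 1 in place of the 4-fluorophenyl group, and the data shown give no reason for the loss itself.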